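Chloro on the Fused Ring of Compound 3

The source may report more compounds than this note shows. Statements on the series, on what has been measured and on what is new or still open speak of the compounds shown alone.

Compound 2 `CN(C)c1ccc(C2CC(c3ccccc3)=NN2C2=NC(=O)/C(=C3\C(=O)Nc4ccccc43)S2)cc1` holds numerically the higher of the two numbers in a functional assay on cells (Cancer cell lines, Homo sapiens) for cytotoxicity, read by sulforhodamine B assay, with a stated time of 48 h (on this read-out higher numbers stand for weaker inhibition of growth and lower numbers for stronger inhibition of growth), giving 270 nM, while compound 1 `O=C1N=C(N2N=C(c3ccccc3)CC2c2ccc(Cl)cc2)S/C1=C1/C(=O)Nc2ccccc21` gives 250 nM; the difference, a 1.1-fold higher number from compound 1 to compound 2 (0.03 log units; within the scatter), lies within the scatter. Compound 3 `CN(C)c1ccc(C2CC(c3ccccc3)=NN2C2=NC(=O)/C(=C3\C(=O)Nc4ccc(Cl)cc43)S2)cc1` differs from compound 2 by chloro in place of hydrogen on an aromatic carbon. Within the data shown here, no measured step touches this ring; the only known step, a 1.1-fold higher number from compound 1 to compound 2 (0.03 log units; within the scatter), alters another place and stays within the scatter. Compound 3 is therefore expected to show no step beyond the scatter, estimated as no change at the digits printed from compound 2 to compound 3 (within the scatter). The estimate for compound 3 is 270 nM, with a range from 110 nM to 650 nM.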

Compound 3, concentration for 50% growth inhibition: 250 nM
For compound 3 the middle estimate is 1.1-fold (0.03 log units) above the measured one, and the stated range covers the measured number.
By their numbers in this assay, from the lowest: compounds 1, 3 and 2 (each within the scatter of the next).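

In this assay, chloro in place of hydrogen on the fused system gives a 1.1-fold lower number from compound 2 to compound 3 (0.03 log units; within the scatter), so this position, unlike the place altered in the earlier step, has now been tested and takes a single chlorine atom with no shift beyond the scatter. Nothing at hand explains this result. As far as these compounds go, whether an amine or a carboxylic acid on this same carbon would also stay within the scatter remains open. So does whether this chloro would act alike with chloro instead of dimethylamino on the other aromatic ring.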